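Replacing the 4-methoxyphenyl group of compound 1

The source may hold more compounds than are shown below. What is called first, only, known or untested is meant among the compounds shown, and "the series" means these compounds.

Measured so far in a functional assay on Jurkat cells (Homo sapiens) for antiproliferative activity, read by MTT assay, with a stated time of 72 h (a lower number here means a stronger inhibitor, a higher number a weaker inhibitor), for three compounds
compound 1 `COc1ccc(-c2ncnn2-c2cc(OC)c(OC)c(OC)c2)cc1` gives 50 nM
compound 2 `COc1cc(-n2ncnc2-c2ccc(OC(F)(F)F)cc2)cc(OC)c1OC` gives > 10000 nM
compound 3 `CCOc1ccc(-c2ncnn2-c2cc(OC)c(OC)c(OC)c2)cc1` gives 5 nM

Compound 1 at 50 nM holds the higher of the two actual numbers, and compound 3 at 5 nM holds the lower. Compound 2 reports only a limit at > 10000 nM and no number.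

The next compound is compound 4 `COc1cc(-n2ncnc2-c2cccc(F)c2)cc(OC)c1OC`, which keeps the shared core but carries 3-fluorophenyl in place of 4-methoxyphenyl on an aromatic carbon and so loses the oxygen on that ring.

Within the data shown here, two measured steps bear on this change, and both alter the group on that oxygen. Trifluoromethyl in place of methyl gave an at least 200-fold higher number from compound 1 to compound 2 (2.30 log units; beyond the scatter) as a large step. Adding methyl to the chain carbon gave a 10-fold lower number from compound 1 to compound 3 (1.00 log units; beyond the scatter) as a modest step. Among the measured compounds shown here, no measured compound lacks the oxygen, so this swap has not been tested directly. The number clearly responds to changes at this group, and the large step of an at least 200-fold higher number from compound 1 to compound 2 (2.30 log units; beyond the scatter) points to a loss in this assay when the methoxy group is disturbed. A large rise is therefore expected, namely a 40-fold higher number from compound 1 to compound 4 (1.60 log units; beyond the scatter) as the estimated step. Compound 4 is expected near 2000 nM with an estimated range from 200 nM to 10000 nM in this measurement.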

Compound 4, half-maximal inhibitory concentration: > 10000 nM
Compound 4: only a limit was reported; the forecaster's own chance of this, stated with the estimate: 30%; middle value at least 5.0-fold (0.69 log units) away from the limit.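

In this assay, among these compounds, the earlier steps all kept the oxygen on this ring and changed only the group attached to it, while the swap to 3-fluorophenyl removes that oxygen altogether and gives an at least 200-fold higher number from compound 1 to compound 4 (2.30 log units; beyond the scatter). The result for compound 4 is a limit and not a number, and the same limit has now appeared twice: the limit of > 10000 nM in this assay, at which 2 of the 4 values shown sit. Among the four compounds, only compound 1 and compound 3, which carry methoxy and ethoxy on this ring, give actual numbers, so this position tolerates little of what has been tried beyond those two groups, and compound 2 and compound 4 cannot be ranked against each other.

This step removes the oxygen and adds a fluorine on the ring in a single change, and the compounds shown do not separate the share of each in the loss. Also open, as far as these compounds go, is how the assay would respond to a plain phenyl group, an amine on this ring, or a longer chain such as propyl on the oxygen.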